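Replacing a bromophenyl arm with a methylthiophene in a sulfone

A few compounds are considered here, and "the series" means these few. Any claim that something is new, unique, unknown or untested is made for them only; others in the source may bear on it.

Two measured compounds frame this account. Compound 1, `Cc1ccc(CS(=O)(=O)/C(=C/c2ccc(Br)cc2)C(=O)c2ccc(Cl)cc2)cc1`, was tested in a functional assay on DU-145 cells (Homo sapiens) for inhibition, read by trypan blue exclusion, with a stated time of 96 h (a higher number here means a weaker inhibitor of growth, a lower number a stronger inhibitor of growth), and gave 25000 nM. The other measured compound, compound 2, `O=C(O)c1ccc(C(=O)/C(=C\c2ccc(F)c([N+](=O)[O-])c2)SCc2ccc(C(F)(F)F)cc2)cc1`, gave 1000 nM in this assay, so compound 1 stands with the higher of the two numbers, and the gap to compound 2 is beyond the usual scatter. Within the data shown here, no single-change pair between the measured compounds is available, so the step to the new compound rests on the structures alone.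

The new compound is compound 3, `Cc1ccc(CS(=O)(=O)/C(=C/c2sccc2C)C(=O)c2ccc(Cl)cc2)cc1`. It differs from compound 1 in one place: 3-methylthiophen-2-yl in place of 4-bromophenyl on a double-bonded chain carbon bound to a double-bonded chain carbon. The group that leaves is a six-membered aromatic ring of carbon only carrying bromine, and the group that enters is a five-membered aromatic ring with one hetero atom carrying a methyl.

The author expects the step of a 1.3-fold lower number from compound 1 to compound 3 (0.10 log units; within the scatter) to be small, with no clear direction and likely within the scatter. Compound 3 is therefore estimated to give about 20000 nM in this assay, within a range from 5000 nM to 60000 nM.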

Compound 3, concentration for 50% growth inhibition: 25000 nM
Estimate against measurement, compound 3: 1.3-fold (0.10 log units) below; the measured number falls inside the stated range.
By their numbers in this assay, from the lowest: compound 2; then compounds 1 and 3 (each within the scatter of the next).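

In this assay, putting 3-methylthiophen-2-yl in place of 4-bromophenyl on a double-bonded chain carbon bound to a double-bonded chain carbon gave no change at the digits printed from compound 1 to compound 3 (within the scatter). Among these compounds, this is the first single-change reading at this place, since the earlier compounds offered no such pair, and it shows that a five-membered aromatic ring with one hetero atom carrying a methyl and a six-membered aromatic ring of carbon only carrying bromine read alike here, even with the bromine gone and a hydrogen-bond acceptor counted on the entering group. Nothing measured alongside these numbers bears on why the reading stays the same.

Compound 2 gives 1000 nM but differs from compound 1 in more than one place, so its distance from compound 1 and compound 3 cannot be tied to any one group. On these data alone, whether this place can move the number at all remains open, for example with an amine or a carboxylic acid on the aromatic ring that sits there.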